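Series notes: trifluoromethyl in place of chloro

The source may report more compounds than this note shows. Statements on the series, on what has been measured and on what is new or still open speak of the compounds shown alone.

Compound 3 `O=C(Nc1cccc(-n2cc(-c3ccncc3)c(-c3ccc(Cl)c(O)c3)n2)c1)Nc1ccc(Cl)c(Cl)c1` stands only as a limit in a functional assay on NCI-H322M cells (Homo sapiens) for inhibition, read by sulforhodamine B assay, with a stated time of 48 h; a higher number here means that more compound is tolerated, a lower number that less compound is tolerated. In this assay compound 3 gives > 32500 nM, a limit of the assay and not a number. The two neighbours of compound 3 are limits as well. In this assay compound 1 `COc1cc(-c2nn(-c3cccc(NC(=O)c4cccc(C(F)(F)F)c4)c3)cc2-c2ccncc2)ccc1Cl` gives > 50000 nM, which is a limit. In this assay compound 2 `COc1cc(-c2nn(-c3cccc(NC(=O)Nc4ccc(Cl)c(Cl)c4)c3)cc2-c2ccncc2)ccc1Cl` gives > 50000 nM, again a limit. The step that the two limits leave unreadable from compound 1 to compound 2 and the step that the two limits leave unreadable from compound 2 to compound 3 cannot be sized, since the three values sit at the limit of > 50000 nM in this assay, at which 2 of the 3 values shown sit, and at the limit of > 32500 nM in this assay, at which 1 of the 3 values shown sits.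

Compound 4 `O=C(Nc1cccc(-n2cc(-c3ccncc3)c(-c3ccc(Cl)c(O)c3)n2)c1)Nc1ccc(Cl)c(C(F)(F)F)c1` differs from compound 3 by trifluoromethyl in place of chloro on an aromatic carbon. Within the data shown here, no measured step covers this exchange, and the two steps that are measured give no size to build on. Compound 4 is therefore expected to stay at or beyond the limit, and a step that the limit leaves unreadable from compound 3 to compound 4 is expected to be no step beyond the scatter. The estimate for compound 4 in this assay is 60000 nM, with a range from 20000 nM to 200000 nM, most likely reported as a limit once more.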

Compound 4, concentration lethal to 50% of the cells: 24700 nM
Compound 4: middle estimate off by 2.4-fold (0.39 log units), on the high side; the measured number falls inside the stated range.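

In this assay, compound 4 is the first of the compounds shown to give a number rather than a limit, which gives this position its first readable comparison. Trifluoromethyl in place of chloro on this aromatic carbon, ortho to a chloro group, gives an at least 1.3-fold lower number from compound 3 to compound 4 (0.11 log units; that floor lies within the scatter), so the change is not shown to go beyond the scatter. Compound 3 remains a limit of the assay, so only a floor can be given for this step: the limit of > 32500 nM in this assay, at which 1 of the 4 values shown sits.

On these data alone, the steps from compound 1 to compound 2 and from compound 2 to compound 3 cannot be read, so the effect of the methyl on the oxygen remains open when trifluoromethyl is present. Also open, as far as these compounds go, is how a nitrile or a methoxy group on this same aromatic carbon would read.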